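This account rests on a few compounds, and the source may have more. Where it says the series, first, only, none or still open, it means among the compounds named here.

Measured so far:
Compound 1, `CCCC[C@H](NC(=O)[C@H](CCCCN)NC(=O)[C@H](CCCNC(=N)N)NC(=O)c1ccc(/C=C2\SC(=O)N(c3ccc(C)cc3)C2=O)cc1)C(N)=O`: 0.66 10^-6 cm/s
Compound 2, `CCCC[C@H](NC(=O)[C@H](CCCCN)NC(=O)[C@H](CCCNC(=N)N)NC(=O)c1ccc(/C=C2\SC(=S)N(C3CCCC3)C2=O)cc1)C(N)=O`: 2.31 10^-6 cm/s

In an ADME assay for permeability, using PAMPA (a higher number here means that the compound crosses the layer faster, a lower number that the compound crosses the layer more slowly), compound 2 gives the higher of the two numbers, and the gap to compound 1 is beyond the usual scatter. Compound 3, `CCCC[C@H](NC(=O)[C@H](CCCCN)NC(=O)[C@H](CCCNC(=N)N)NC(=O)c1ccc(/C=C2\SC(=S)N(c3ccc(OC)cc3)C2=O)cc1)C(N)=O`, has not been measured yet. It differs from compound 2 by 4-methoxyphenyl in place of cyclopentyl on an amide-type nitrogen in a ring. Compound 1 differs from compound 2 in more than one place, so its value alone cannot show what an aromatic ring on this nitrogen does. A modest downward step a 1.7-fold lower number from compound 2 to compound 3 (0.22 log units; within the scatter) is expected, though one that may stay within the scatter. Compound 3 is estimated at 1.4 10^-6 cm/s, between 0.5 10^-6 cm/s and 3.2 10^-6 cm/s.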

Compound 3, apparent permeability: 0.59 10^-6 cm/s
Compound 3: middle estimate off by 2.4-fold (0.38 log units), on the high side; measured number inside the range.
By their numbers in this assay, from the lowest: compounds 3 and 1 (each within the scatter of the next); then compound 2.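

In this assay, putting 4-methoxyphenyl in place of cyclopentyl on the amide-type nitrogen in the ring gives a 3.9-fold lower number from compound 2 to compound 3 (0.59 log units; beyond the scatter). With the rest of the molecule unchanged, this single position can therefore move the read-out beyond the usual scatter, which compound 1 could not show because it differs from compound 2 in more than one place. Nothing available explains why the number falls. Still open, on these data alone, is whether the step comes from the aromatic ring or its methoxy group, which a plain phenyl on this nitrogen would help separate. As far as these compounds go, how cyclohexyl or an open butyl chain would read there also stays open.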